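This account rests on a few compounds, and the source may have more. Where it says the series, first, only, none or still open, it means among the compounds named here.

Measured so far:
Compound 1 `COc1ccc(N(C)c2ccnc(Cl)n2)cc1F`: 844 nM
Compound 2 `COc1ccc(N(C)c2ccnc(Cl)n2)cc1Cl`: 2630 nM

In a functional assay on HepG2 cells (Homo sapiens) for antiproliferative activity, read by MTT assay, with a stated time of 48 h (on this read-out lower numbers stand for stronger inhibition and higher numbers for weaker inhibition), compound 2 gives 2630 nM, the higher of the two numbers, and its nearest neighbour is compound 1 at 844 nM.

Compound 3 `COc1ccc(N(C)c2ccnc(Cl)n2)cc1[N+](=O)[O-]` has not been measured. It has nitro in place of chloro on an aromatic carbon, ortho to a methoxy group: nitro in place of chloro on an aromatic carbon.

Among the compounds with values here, only one measured step bears on this change: a 3.1-fold higher number from compound 1 to compound 2 (0.49 log units; beyond the scatter), a modest swap of chloro in place of fluoro on an aromatic carbon. Within the data shown here, no measured compound carries nitro, so the direction in this assay remains open. A step of similar or smaller size is expected, with a slight lean towards a lower number. The estimated step is a 1.5-fold lower number from compound 2 to compound 3 (0.16 log units; within the scatter). For compound 3 the expected value is 1800 nM, with an estimated range of 600 nM to 6000 nM.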

Compound 3, half-maximal inhibitory concentration: 6120 nM
Estimate against measurement, compound 3: 3.4-fold (0.53 log units) below; measured number above the stated range.
By their numbers in this assay, from the lowest: compound 1; then compound 2; then compound 3.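

In this assay the position ortho to a methoxy group now carries a third group, and nitro in place of chloro gives a 2.3-fold higher number from compound 2 to compound 3 (0.37 log units; beyond the scatter) in the same direction as the earlier halogen swap. Against fluoro, the same nitro change gives a 7.3-fold higher number from compound 1 to compound 3 (0.86 log units; beyond the scatter) and is the largest step in the series so far. With every step beyond the scatter, the three compounds fall in the order fluoro, chloro, nitro from the lowest number to the highest, none goes against it, and nothing available explains the order.

As far as these compounds go, whether any group at this position gives a lower number than fluoro remains open, for example an amine, a hydroxyl or a methyl. From the compounds shown here alone, it is also open whether this order survives a change elsewhere on the shared core.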